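Changing the Amide Side Chain and Cytotoxicity

The source may report more compounds than this note shows. Statements on the series, on what has been measured and on what is new or still open speak of the compounds shown alone.

- Compound 1 `C/C=C/C(=O)Nc1cccc(Oc2nc(Nc3ccn(C)n3)nc3c2CSCC3)c1` gives > 50000 nM (a limit)
- Compound 2 `CC(C)/C=C/C(=O)Nc1cccc(Oc2nc(Nc3ccn(C)n3)nc3c2CSCC3)c1` gives > 50000 nM (a limit)

In an ADME assay on L02 cells (Homo sapiens) for cytotoxicity, read by MTT assay, with a stated time of 72 h (on this read-out lower numbers stand for stronger inhibition and higher numbers for weaker inhibition), compound 2 gives > 50000 nM as its result, which is a limit and not a number. Both measured compounds sit at that same point: the limit of > 50000 nM in this assay, at which 2 of the 2 values shown sit.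

Compound 3 `C=C(F)C(=O)Nc1cccc(Oc2nc(Nc3ccn(C)n3)nc3c2CSCC3)c1` changes the side chain again: 1-fluoroethenyl in place of 3-methylbut-1-en-1-yl on a carbonyl carbon. In words, this places 1-fluoroethenyl in place of 3-methylbut-1-en-1-yl on a carbonyl carbon.

Within the data shown here, only one measured step bears on this change, and it also lies in the side chain: a step that the two limits leave unreadable from compound 1 to compound 2. It offers no size to carry over, and the new group is unmeasured, so the forecast stays loose. No clear shift is expected, though a small move towards stronger inhibition is possible. The expected change is an at least 1.1-fold lower number from compound 2 to compound 3 (0.04 log units; that floor lies within the scatter) as a rough estimate.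

Compound 3 is estimated at 45000 nM with an expected range of 15000 nM to 100000 nM in this assay.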

Compound 3, half-maximal inhibitory concentration: 47800 nM
Compound 3: middle estimate off by 1.1-fold (0.03 log units), on the low side; the range from low to high includes it.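

Placing 1-fluoroethenyl on the carbonyl carbon instead of 3-methylbut-1-en-1-yl gives an at least 1.0-fold lower number from compound 2 to compound 3 (0.01 log units; that floor lies within the scatter), and placing it there instead of prop-1-en-1-yl gives an at least 1.0-fold lower number from compound 1 to compound 3 (0.01 log units; that floor lies within the scatter). Both floors lie within the scatter, so neither step shows a real gain in inhibition, and this side-chain change need not shift the result by much. What is new is that compound 3 gives a number rather than a limit in this assay, while the other two compounds do not: the limit of > 50000 nM in this assay, at which 2 of the 3 values shown sit.

From the compounds shown here alone, the true gaps from compound 1 and compound 2 to compound 3 stay unknown, and the step between compound 1 and compound 2 cannot be read. Going by these compounds, whether a plain ethenyl group, or a chain carrying a dimethylamino group, on the same carbonyl carbon would give a number in this assay remains open.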